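This account rests on a few compounds, and the source may have more. Where it says the series, first, only, none or still open, it means among the compounds named here.

Compound 1 (`O=[N+]([O-])c1ccc(CN2CCC(n3cc(CC(OCc4cc(-c5ccc(F)cc5)no4)c4ccc(Br)cc4)nn3)CC2)cc1`) was tested in a functional assay on PC-3 cells (Homo sapiens) for cytotoxicity, with a stated time of 48 h; on this read-out higher numbers stand for weaker inhibition and lower numbers for stronger inhibition. In this assay compound 1 gives > 25000 nM, which is a limit of the assay and not a number. As far as these compounds go, compound 1 therefore stands at the limit of > 25000 nM in this assay, at which 1 of the 2 values shown sits, and its true value is unknown beyond that. Compound 2 (`O=[N+]([O-])c1ccc(CN2CCC(n3cc(CC(OCc4cc(-c5cccc(F)c5)no4)c4ccc(Br)cc4)nn3)CC2)cc1`) carries a 3-fluorophenyl in place of the 4-fluorophenyl on an aromatic carbon, and in this assay compound 2 gives 9000 nM. The measured step is an at least 2.7-fold lower number from compound 1 to compound 2 (0.44 log units; beyond the scatter). Compound 3 (`COc1ccccc1-c1cc(COC(Cc2cn(C3CCN(Cc4ccc([N+](=O)[O-])cc4)CC3)nn2)c2ccc(Br)cc2)on1`) has not yet been measured in this assay; it differs from compound 1 by 2-methoxyphenyl in place of 4-fluorophenyl on an aromatic carbon. Within the data shown here, the change falls on the same aromatic carbon as the one from compound 1 to compound 2, but the entering group is a 2-methoxyphenyl rather than a 3-fluorophenyl, so the single measured step gives only a loose guide to direction and size. Because compound 1 sits at the limit of > 25000 nM in this assay, at which 1 of the 2 values shown sits, only a lower number could be seen as a step beyond the scatter. Compound 3 is expected to give about 15000 nM in this assay, with a range from 4000 nM to 60000 nM. The expected step is an at least 1.6-fold lower number from compound 1 to compound 3 (0.22 log units; that floor lies within the scatter).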

Compound 3, half-maximal inhibitory concentration: > 25000 nM
Compound 3: a limit, no number; the forecaster's own chance of this, stated with the estimate: 45%; middle value at least 1.6-fold (0.22 log units) away from the limit.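

In this assay compound 3 gives > 25000 nM, which is a limit of the assay and not a number. Among these compounds, the one step that can be read at this position is an at least 2.7-fold higher number from compound 2 to compound 3 (0.44 log units; beyond the scatter), so among the three groups tested on this aromatic carbon of the five-membered ring, only the 3-fluorophenyl yields a number, while the 2-methoxyphenyl joins the 4-fluorophenyl at the limit. The step between compound 1 and compound 3 cannot be read, because both compounds sit at the same limit: the limit of > 25000 nM in this assay, at which 2 of the 3 values shown sit.

The compounds shown leave open whether what sets the 3-fluorophenyl apart is the fluorine itself or the place of that fluorine on the phenyl ring, and a 3-methoxyphenyl or a 3-chlorophenyl on the same carbon would bear on that question. Also open, as far as these compounds go, are how a plain phenyl would read here and how compound 1 and compound 3 truly compare, as their real values lie out of reach of this read-out.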